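The source may hold more compounds than are shown below. What is called first, only, known or untested is meant among the compounds shown, and "the series" means these compounds.

Measured so far in a physicochemical assay for lipophilicity; on this read-out higher numbers stand for higher lipophilicity and lower numbers for lower lipophilicity:
Compound 1 `CN(C)/N=N/c1ccc(F)cc1`: compound 1 gives 2.73.
Compound 2 `CN(C)/N=N/c1cccc(C(N)=O)c1`: compound 2 gives 1.21.
Compound 3 `CN(C)/N=N/c1c(Cl)cccc1Cl`: compound 3 gives 4.01.

Compound 3 stands highest of the three numbers in this assay; compound 1 is nearest and compound 2 furthest, both lower and both beyond the scatter. No two of these compounds differ in only one place, so no single step has been measured in the series.

Compound 4 `CN(C)/N=N/c1ccccc1Cl` is the next compound to be measured in this assay. Compared with compound 3 the change is hydrogen in place of chloro on an aromatic carbon. With hydrogen in place of chloro on an aromatic carbon, a moderate fall in this assay, beyond the scatter, is expected; the expected step is a number 0.71 log units lower from compound 3 to compound 4 (beyond the scatter). Compound 4 is estimated at 3.3, within a range from 2.9 to 3.7.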

Compound 4, partition coefficient: 2.97
Compound 4: the middle estimate sits 0.33 log units above what was measured; the range from low to high includes it.
By their numbers in this assay, from the lowest: compound 2; then compounds 1 and 4 (each within the scatter of the next); then compound 3.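

In this assay the series has its first single-place step: hydrogen in place of chloro on an aromatic carbon, ortho to a group of 5 heavy atoms and meta to a chloro group, gives a number 1.04 log units lower from compound 3 to compound 4 (beyond the scatter), a large change. This step is read in one pair only, with the other chloro group still in place. Nothing at hand accounts for its size.

Open: whether a step of this size holds at this position for a methyl, a methoxy or an amine in place of chloro, and whether it holds when no second chloro group remains.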